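A few compounds are considered here, and "the series" means these few. Any claim that something is new, unique, unknown or untested is made for them only; others in the source may bear on it.

Working notes on the series.

Compound 1 `Cc1ccc(-c2nn(-c3ccccc3)cc2-c2nc3ccccc3n2S(=O)(=O)c2ccc(Cl)cc2)cc1` is the reference point. In a functional assay on MCF7 cells (Homo sapiens) for antiproliferative activity, read by MTT assay, with a stated time of 24 h (on this read-out lower numbers stand for stronger inhibition and higher numbers for weaker inhibition), compound 1 gives 5930 nM. Compound 2 `Cc1ccc(-c2nn(-c3ccccc3)cc2-c2nc3ccccc3n2S(=O)(=O)c2ccc(Br)cc2)cc1` differs from compound 1 by bromo in place of chloro on an aromatic carbon, a change sitting at the place described there. In this assay compound 2 gives 3160 nM, which is a step of a 1.9-fold lower number from compound 1 to compound 2 (0.27 log units; within the scatter). Compound 3 `O=S(=O)(c1ccc(Cl)cc1)n1c(-c2cn(-c3ccccc3)nc2-c2ccc(C(F)(F)F)cc2)nc2ccccc21` keeps the chloro of compound 1 and its core differs from the core of compound 1 by trifluoromethyl in place of methyl on an aromatic carbon. In this assay compound 3 gives 4320 nM, a step of a 1.4-fold lower number from compound 1 to compound 3 (0.14 log units; within the scatter), so the three measured numbers all sit close to one another and nothing can be said about their order.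

Compound 4 `O=S(=O)(c1ccc(Br)cc1)n1c(-c2cn(-c3ccccc3)nc2-c2ccc(C(F)(F)F)cc2)nc2ccccc21` has not yet been measured. It differs from compound 3 by bromo in place of chloro on an aromatic carbon. Among the measured compounds shown here, this is the same change as the one that separates compound 1 from compound 2, at the same kind of place, only made on the core of compound 3 instead of the core of compound 1. With a single example of this change at hand, its step is the best guide. For the measured compounds named here, for compound 4 in this assay the step is expected to be about a 1.5-fold lower number from compound 3 to compound 4 (0.19 log units; within the scatter), beside the earlier one, because a 1.9-fold lower number from compound 1 to compound 2 (0.27 log units; within the scatter) is the only precedent and it stayed within the scatter, so no larger shift is assumed. Compound 4 is therefore estimated at 2800 nM, with a plausible range from 1300 nM to 6500 nM.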

Compound 4, half-maximal inhibitory concentration: 2470 nM
Compound 4: middle estimate off by 1.1-fold (0.05 log units), on the high side; measured number inside the range.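

Bromo in place of chloro on an aromatic carbon, now made on the core of compound 3, gives a 1.7-fold lower number from compound 3 to compound 4 (0.24 log units; within the scatter) in this assay, and this step does not differ from the one on the core of compound 1: the same change on two cores in this assay, a 1.9-fold lower number (0.27 log units; within the scatter) from compound 1 to compound 2 and a 1.7-fold lower number (0.24 log units; within the scatter) from compound 3 to compound 4, 1.1-fold (0.03 log units) apart, within the scatter of two such steps. Read the other way round, trifluoromethyl in place of methyl on an aromatic carbon gives a 1.3-fold lower number from compound 2 to compound 4 (0.11 log units; within the scatter), and this step also agrees with its earlier counterpart: the same change on two cores in this assay, a 1.4-fold lower number (0.14 log units; within the scatter) from compound 1 to compound 3 and a 1.3-fold lower number (0.11 log units; within the scatter) from compound 2 to compound 4, 1.1-fold (0.03 log units) apart, within the scatter of two such steps. Among the compounds shown here, each change therefore carries from one core to the other without a detectable difference, but all four steps stay within the scatter, so the agreement is one between small steps, it does not show that either change has a real effect on the number, it gives no order among the four compounds, and it rests on only two cores with one pair of steps for each change.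

The compounds shown leave open whether a step beyond the scatter would carry across these cores in the same way, since only chloro and bromo appear on the sulfonyl-bound ring and only methyl and trifluoromethyl on the other varied ring. From the compounds shown here alone, an amine, a carboxylic acid or a methoxy group at either of these places remains untested in this set, as does any replacement of the unsubstituted phenyl on the shared core.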